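The compounds below may be only part of what the source reports. "The series", "measured", "known", "first", "only" and "open" are said of these compounds alone.

Within the data shown here, in a functional assay on HT-29 cells (Homo sapiens) for antiproliferative activity, read by sulforhodamine B assay, with a stated time of 72 h (a lower number here means a stronger inhibitor, a higher number a weaker inhibitor), only two compounds have numbers so far. Compound 1 (`Cc1cc(C)nc(NS(=O)(=O)c2ccc(Nc3nncc4ccccc34)cc2)n1`) gives 3.3 nM and compound 2 (`Fc1ccc(Nc2nncc3ccccc23)cc1`) gives 2.1 nM in this pairing, and the two values lie within the usual scatter of each other, so neither can be placed ahead. Compound 3 (`Cc1cc(NS(=O)(=O)c2ccc(Nc3nncc4ccccc34)cc2)no1`) has not yet been measured. It keeps the core of compound 1 and differs only on a sulfonamide nitrogen, where 5-methyl-1,2-oxazol-3-yl stands in place of 4,6-dimethylpyrimidin-2-yl (5-methyl-1,2-oxazol-3-yl in place of 4,6-dimethylpyrimidin-2-yl on a sulfonamide nitrogen). Among the measured compounds shown here, no measured pair shows directly what this exchange does. Still, compound 2 carries no sulfonamide and gives 2.1 nM, within the scatter of compound 1 at 3.3 nM, which suggests that the number need not depend heavily on this group. No change beyond the scatter is therefore expected, and the estimated step is small (a 1.2-fold higher number from compound 1 to compound 3 (0.08 log units; within the scatter)). For compound 3 the estimated value is 4 nM in this assay, with 1 nM to 20 nM as the expected range.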

Compound 3, half-maximal inhibitory concentration: 23 nM
The estimate for compound 3 lay 5.8-fold (0.76 log units) below the measured number; the measured number lies above the stated range.
By their numbers in this assay, from the lowest: compounds 2 and 1 (each within the scatter of the next); then compound 3.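

In this assay, among these compounds, the exchange of 4,6-dimethylpyrimidin-2-yl for 5-methyl-1,2-oxazol-3-yl on a sulfonamide nitrogen gives a 7.0-fold higher number from compound 1 to compound 3 (0.84 log units; beyond the scatter), the first direct reading at this position, and it shows that with the rest of compound 1 held fixed, the group on this nitrogen does affect the number. The step comes with a six-membered aromatic ring giving way to a five-membered one and with fewer heavy atoms, while the counts of hydrogen-bond donors and acceptors stay the same and neither group carries a net charge, so those unchanged counts alone do not keep the number in place. No measurement shown here accounts for the rise.

With a single exchange, the compounds shown leave open whether the rise goes with the ring size, the ring oxygen or the number of methyl groups. They also leave open where other groups on this nitrogen, such as an unsubstituted phenyl, a pyridin-2-yl or an unsubstituted pyrimidin-2-yl, would fall relative to these two.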